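The compounds below may be only part of what the source reports. "The series", "measured", "known", "first", "only" and "open" are said of these compounds alone.

Four compounds share the core of compound 1 `C=CCn1c(-c2ccc(OC)cc2COCOC)cc2ccccc2c1=O`: compound 2 `C=CCn1c(-c2cc(OC)c(OC)cc2COCOC)cc2ccccc2c1=O`, compound 3 `COCOCc1cc(OC)ccc1-c1cc2ccccc2c(=O)[nH]1` and the still unmeasured compound 4 `C=CCn1c(-c2cc(OC)c(OC)cc2C=C)cc2ccccc2c1=O`. In a functional assay on SK-OV-3 cells (Homo sapiens) for cytotoxicity, read by MTT assay, with a stated time of 48 h (on this read-out higher numbers stand for weaker inhibition and lower numbers for stronger inhibition), compound 1 reads > 100000 nM, which is a limit of the assay and not a number. In this assay compound 2 gives 37700 nM and compound 3 gives 75500 nM, two values within the usual scatter of each other.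

Compound 4 departs from compound 2 at a single place: vinyl in place of (methoxymethoxy)methyl on an aromatic carbon. It carries vinyl in place of (methoxymethoxy)methyl on an aromatic carbon.

Among the measured compounds shown here, two measured steps bear on this only indirectly. Adding a methoxy group gives an at least 2.6-fold lower number from compound 1 to compound 2 (0.42 log units; beyond the scatter), which is beyond the scatter, while hydrogen in place of allyl on an aromatic nitrogen gives an at least 1.3-fold lower number from compound 1 to compound 3 (0.12 log units; that floor lies within the scatter), whose floor lies within it. Neither step touches the (methoxymethoxy)methyl group, which all three measured compounds carry, so the data give no direct size for this exchange.

With compound 2 as the anchor, no move beyond the scatter is expected. The expected change is a 1.3-fold lower number from compound 2 to compound 4 (0.10 log units; within the scatter), in the direction of a slightly lower number. For compound 4 the estimate is 30000 nM, with an expected range from 9000 nM to 100000 nM.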

Compound 4, half-maximal inhibitory concentration: 35500 nM
Compound 4: middle estimate off by 1.2-fold (0.07 log units), on the low side; the measured number falls inside the stated range.
By their numbers in this assay, from the lowest: compounds 4, 2 and 3 (each within the scatter of the next, the first and the last beyond it). At a limit, above all of these: compound 1.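

Among the compounds shown here, the exchange at this position, on an aromatic carbon ortho to a large group, gives the first direct reading for this group, which all the earlier compounds carried: in this assay, vinyl in place of (methoxymethoxy)methyl gives a 1.1-fold lower number from compound 2 to compound 4 (0.03 log units; within the scatter). The pair shows that, on this background, the read-out stays within the scatter although the group shrinks from five heavy atoms with two hydrogen-bond acceptors to two heavy atoms with none, so the (methoxymethoxy)methyl group is not needed to hold the number where compound 2 has it. From the compounds shown here alone, the top of the series remains open-ended, since compound 1 stands at a limit of the assay and not at a number: the limit of > 100000 nM in this assay, at which 1 of the 4 values shown sits.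

Going by these compounds, only these two groups are compared at this position, and only with the second methoxy group and the allyl on the nitrogen both present, so it stays open whether vinyl would read the same on the background of compound 1 or compound 3. On these data alone, it is also open whether an amine, a carboxylic acid or a longer carbon chain at this place would move the number beyond the scatter.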